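Swapping the Aryl Group on a Weak Growth Inhibitor

A few compounds are considered here, and "the series" means these few. Any claim that something is new, unique, unknown or untested is made for them only; others in the source may bear on it.

Measured in a functional assay on DU-145 cells (Homo sapiens) for inhibition, read by trypan blue exclusion, with a stated time of 96 h; a lower number here means a stronger inhibitor of growth, a higher number a weaker inhibitor of growth:
Compound 1, `COc1ccc(/C=C(/SCc2ccc(Cl)cc2)C(=O)c2ccc(Br)cc2)cc1`, gives 10000 nM.
Compound 2, `Cc1ccc(S(=O)(=O)/C(=C/c2sccc2C)C(=O)c2ccc(Br)cc2)cc1`, gives 25000 nM.
Compound 3, `COc1ccc(/C=C(/Sc2ccc(Br)cc2)C(=O)c2ccc(Br)cc2)cc1`, gives 25000 nM.

Compound 3 stands level with compound 2 at the digits shown, and together these two give the highest numbers of the three, meaning the weakest growth inhibition. Within the data shown here, compound 1 sits below them; the only step that can be traced to a single change runs from compound 1 to compound 3: a 2.5-fold higher number from compound 1 to compound 3 (0.40 log units; beyond the scatter).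

Compound 4, `O=C(/C(=C\c1ccc(Cl)cc1Cl)Sc1ccc(Br)cc1)c1ccc(Br)cc1`, is not yet measured. It differs from compound 3 in one place: 2,4-dichlorophenyl in place of 4-methoxyphenyl on a double-bonded chain carbon bound to a double-bonded chain carbon. Among the measured compounds shown here, no measured step bears on this change. For the measured compounds named here, the one step available concerns the group on a sulfur, not the group on the double-bonded chain carbon, and compound 2 differs from compound 3 in more than one place, so its value shows only that a different ring in that position gave a number level with compound 3. With nothing pointing either way, the expected step of no change at the digits printed from compound 3 to compound 4 (within the scatter) is none beyond the scatter. Compound 4 is therefore estimated at 25000 nM, with a range from 8000 nM to 60000 nM.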

Compound 4, concentration for 50% growth inhibition: 1000 nM
Beside the measured number, compound 4's estimate is 25-fold (1.40 log units) above it; measured number below the stated range.
By their numbers in this assay, from the lowest: compound 4; then compound 1; then compounds 2 and 3 (each within the scatter of the next).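

Among these compounds, changing 4-methoxyphenyl to 2,4-dichlorophenyl on a double-bonded chain carbon bound to a double-bonded chain carbon gives a 25-fold lower number from compound 3 to compound 4 (1.40 log units; beyond the scatter) in this assay and is a much larger move than the change on the sulfur, which gave a 2.5-fold higher number from compound 1 to compound 3 (0.40 log units; beyond the scatter) and was the only single change that could be read before. Among the compounds shown here, this is the first sign that growth inhibition responds strongly to the aryl group at this place, and the swap keeps the heavy-atom count and the single aromatic ring while replacing the oxygen of the methoxy group with two chlorine atoms. Nothing measured here explains why this swap has so large an effect, so it remains an observation about this one pair.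

The compounds shown leave open whether both chlorines are needed or whether removing the methoxy group alone would matter, a question that plain phenyl or 4-chlorophenyl at this place could help to separate. Also open, from the compounds shown here alone, are how an amine or a carboxylic acid on this ring would behave and whether 2,4-dichlorophenyl has the same effect with the 4-chlorobenzyl group of compound 1 on the sulfur.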